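Compound 3: 4-methylphenyl in place of 3-fluorophenyl

A few compounds are considered here, and "the series" means these few. Any claim that something is new, unique, unknown or untested is made for them only; others in the source may bear on it.

Within the data shown here, in a functional assay on A549 cells (Homo sapiens) for antiproliferative activity, read by MTT assay, with a stated time of 72 h (on this read-out lower numbers stand for stronger inhibition and higher numbers for weaker inhibition), compound 2 (`CCNC(=O)c1cc(Oc2ccc(NC(=O)c3nn(-c4cccc(F)c4)c(=O)cc3C)cc2)ccn1`) gives 7410 nM, the lower of the two numbers so far, while compound 1 (`CCNC(=O)c1cc(Oc2ccc(NC(=O)c3nn(-c4ccccc4C)c(=O)cc3C)cc2)ccn1`) gives 34800 nM. Compound 3 (`CCNC(=O)c1cc(Oc2ccc(NC(=O)c3nn(-c4ccc(C)cc4)c(=O)cc3C)cc2)ccn1`) carries 4-methylphenyl in place of 3-fluorophenyl on an aromatic nitrogen. Among the measured compounds shown here, only one measured step bears on this change: a 4.7-fold lower number from compound 1 to compound 2 (0.67 log units; beyond the scatter), modest but beyond the scatter, with 3-fluorophenyl replacing 2-methylphenyl at the same nitrogen. For the measured compounds named here, no 4-methylphenyl compound has been measured, so a small rise is expected, a 1.6-fold higher number from compound 2 to compound 3 (0.21 log units; within the scatter). For compound 3 the estimate is 12000 nM, with an expected range of 5000 nM to 30000 nM.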

Compound 3, half-maximal inhibitory concentration: 11600 nM
Estimate against measurement, compound 3: 1.0-fold (0.01 log units) above, and the stated range covers the measured number.
By their numbers in this assay, from the lowest: compounds 2 and 3 (each within the scatter of the next); then compound 1.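

In this assay, 4-methylphenyl and 3-fluorophenyl on the aromatic nitrogen cannot be told apart, with a 1.6-fold higher number from compound 2 to compound 3 (0.19 log units; within the scatter). Against 2-methylphenyl, the same 4-methylphenyl group gives a 3.0-fold lower number from compound 1 to compound 3 (0.48 log units; beyond the scatter), so among these compounds a methyl group on the phenyl ring does not by itself bring the higher number of compound 1. Nothing on hand accounts for either step.

Still open, as far as these compounds go, is whether an amine, a carboxylic acid or a longer chain on this phenyl ring would lower the number. Also open, from the compounds shown here alone, is how a saturated ring such as cyclohexyl would compare at this nitrogen.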